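Removing one phosphate from a weakly active uridine analogue

A few compounds are considered here, and "the series" means these few. Any claim that something is new, unique, unknown or untested is made for them only; others in the source may bear on it.

All four compounds here share a uridine-like core carrying a chain of phosphate groups, and they are compared in an in vitro functional assay on 1321-N1 cells for agonist activity at P2Y purinoceptor 4 (Homo sapiens); on this read-out higher numbers stand for an effect only at larger amounts of compound and lower numbers for an effect already at smaller amounts. Compound 1, with the structure `O=c1ccn([C@@H]2O[C@H](COP(=O)(O)OP(=O)(O)OP(=O)(O)O)[C@@H](O)[C@H]2O)c(=S)[nH]1`, carries three phosphate units and in this assay gives 1770 nM. Compound 2, with the structure `O=c1ccn([C@@H]2O[C@H](COP(=O)(O)OP(=O)(O)O)[C@@H](O)[C@H]2O)c(=S)[nH]1`, differs from compound 1 by a hydrogen atom in place of a group of 4 heavy atoms (3 oxygen, 1 phosphorus; no ring), on an oxygen. For compound 2 this assay reports only a limit, > 1000 nM, so the step that the limit leaves unreadable from compound 1 to compound 2 cannot be sized; this follows from the limit of > 1000 nM in this assay, at which 1 of the 3 values shown sits. Compound 3, with the structure `Cn1c(=O)ccn([C@@H]2O[C@H](COP(=O)(O)OP(=O)(O)O)[C@@H](O)[C@H]2O)c1=O`, has a core that differs from that of compound 1 in a way that is not broken down here. For compound 3 this assay again reports only a limit, > 100000 nM, as stated in the limit of > 100000 nM in this assay, at which 1 of the 3 values shown sits.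

Compound 4, with the structure `Cn1c(=O)ccn([C@@H]2O[C@H](COP(=O)(O)O)[C@@H](O)[C@H]2O)c1=O`, has not yet been measured. Within the data shown here, it differs from compound 3 by a hydrogen atom in place of a group of 4 heavy atoms (3 oxygen, 1 phosphorus; no ring), on an oxygen, the same change as the one from compound 1 to compound 2, made at the same kind of place. Because compound 3 already sits at the limit > 100000 nM, and because the earlier step that the limit leaves unreadable from compound 1 to compound 2 could not be read, the step of a number no higher from compound 3 to compound 4 (the limit leaves the size open) is only an expectation that compound 4 stays at that limit. On this basis compound 4 is estimated to give about 100000 nM in this assay, most likely reported again only as a limit.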

Compound 4, half-maximal effective concentration: > 100000 nM
Compound 4: only a limit was reported; the forecaster's own chance of this, stated with the estimate: 90%; the middle value lies on the limit itself.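

No size can be read for the step from compound 3 to compound 4, since each of the two gives only a limit and not a number, and both give the same limit: the limit of > 100000 nM in this assay, at which 2 of the 4 values shown sit.

The compounds shown leave open whether replacing this phosphate unit with a hydrogen atom changes the effect in this assay at all, on either the core of compound 1 or that of compound 3.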